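A ring swap on a compound held at the limit

The compounds below may be only part of what the source reports. "The series", "measured", "known", "first", "only" and "open" are said of these compounds alone.

Compound 1 `Cn1c(N)c(-c2nc3ccccc3[nH]2)c2nc(C#N)c(C#N)nc21`: > 50000 nM
Compound 2 `CN(C)CCn1c(N)c(-c2nc3ccccc3[nH]2)c2nc(C#N)c(C#N)nc21`: > 50000 nM

In a functional assay on A549 cells (Homo sapiens) for antiproliferative activity, read by MTT assay, with a stated time of 48 h (on this read-out lower numbers stand for stronger inhibition and higher numbers for weaker inhibition), compound 2 gives > 50000 nM, which is a limit and not a number. Compound 1 gives > 50000 nM, also a limit. Going by the values given here, the one measured step, a step that the two limits leave unreadable from compound 1 to compound 2, has no readable size, so it offers no guide to how large the next change might be. Compound 3 `CN(C)CCn1c(N)c(-c2nc3ccccc3s2)c2nc(C#N)c(C#N)nc21` carries 1,3-benzothiazol-2-yl in place of 1H-benzimidazol-2-yl on an aromatic carbon. Among the compounds with values here, no measured step touches this place in the structure, and the only evidence is the limit of > 50000 nM in this assay, at which 2 of the 2 values shown sit. The expectation is therefore no change beyond the scatter in this assay, an expected a number no higher from compound 2 to compound 3 (the limit leaves the size open), though a gain in potency cannot be excluded. The estimate for compound 3 is 50000 nM, with an expected range of 15000 nM to 100000 nM.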

Compound 3, half-maximal inhibitory concentration: > 50000 nM
Compound 3 gave a limit, no number (the forecaster's own chance of this, stated with the estimate: 70%); the middle value sits exactly at the limit.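

Going by these compounds alone, compound 2 and compound 3 both sit at a limit of the assay rather than at a number, so no step between them can be read. The compounds shown leave open how strongly any of them acts in this assay, and whether 1,3-benzothiazol-2-yl in place of 1H-benzimidazol-2-yl changes that at all.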